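This account rests on a few compounds, and the source may have more. Where it says the series, first, only, none or still open, it means among the compounds named here.

Measured compounds:
compound 1 `CCCCN(C)c1nc(C(C)(C)C)ccc1CNC(=O)C(C)c1ccc(NS(C)(=O)=O)c(F)c1` — 1.2 nM
compound 2 `CCCCOc1nc(C(C)(C)C)ccc1CNC(=O)C(C)c1ccc(NS(C)(=O)=O)c(F)c1` — 0.9 nM
compound 3 `CC(C)CCOc1nc(C(C)(C)C)ccc1CNC(=O)C(C)c1ccc(NS(C)(=O)=O)c(F)c1` — 0.8 nM

Within the data shown here, in an assay on cells for antagonist activity at transient receptor potential cation channel subfamily V member 1 (Homo sapiens), read by FLIPR and calcium flux, with a stated time of 6 min (a lower number here means a stronger inhibitor, a higher number a weaker inhibitor), compound 3 holds the lowest of the three numbers, yet its distance to the others is small: a 1.1-fold lower number from compound 2 to compound 3 (0.05 log units; within the scatter) and a 1.5-fold lower number from compound 1 to compound 3 (0.18 log units; within the scatter) both sit within the scatter, so no compound can be called the strongest. The new compound 4 `CCCCSc1nc(C(C)(C)C)ccc1CNC(=O)C(C)c1ccc(NS(C)(=O)=O)c(F)c1` is made from compound 3 by butylsulfanyl in place of isopentyloxy on an aromatic carbon. Among the measured compounds shown here, the steps that bear on this swap of the group beside the ring nitrogen are a 1.3-fold lower number from compound 1 to compound 2 (0.12 log units; within the scatter) and a 1.5-fold lower number from compound 1 to compound 3 (0.18 log units; within the scatter), where one linking atom replaced another, and a 1.1-fold lower number from compound 2 to compound 3 (0.05 log units; within the scatter), a change in chain shape; none moved beyond the scatter. The expected step for compound 4 is therefore a 1.5-fold higher number from compound 3 to compound 4 (0.18 log units; within the scatter), nothing beyond the scatter. Compound 4 is estimated at 1.2 nM, between 0.4 nM and 4 nM.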

Compound 4, inhibition constant: 3.2 nM
Compound 4: the middle estimate sits 2.7-fold (0.43 log units) below what was measured; low and high end bracket the measured number.
By their numbers in this assay, from the lowest: compounds 3, 2 and 1 (each within the scatter of the next); then compound 4.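

At this position next to the ring nitrogen, swapping between the oxygen and nitrogen links stayed within the scatter, but the sulfur link moves beyond it, with a 3.6-fold higher number from compound 2 to compound 4 (0.55 log units; beyond the scatter) when only oxygen becomes sulfur on the same butyl chain. The other two comparisons point the same way, with a 2.7-fold higher number from compound 1 to compound 4 (0.43 log units; beyond the scatter) and a 4.0-fold higher number from compound 3 to compound 4 (0.60 log units; beyond the scatter) also modest but beyond the scatter. Nothing available explains why the sulfur link differs. Still open, on these data alone, is whether a shorter chain on sulfur, such as methylsulfanyl, or a ring such as piperidine at this position would keep the number low.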